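Hydroxymethyl for hydroxy at the assay limit

The source may report more compounds than this note shows. Statements on the series, on what has been measured and on what is new or still open speak of the compounds shown alone.

compound 1 `Nc1n[nH]c(N)c1/N=N/c1ccccc1[N+](=O)[O-]`: > 100000 nM (a limit)
compound 2 `Nc1n[nH]c(N)c1/N=N/c1ccccc1O`: > 100000 nM (a limit)

In a functional assay on MCF7 cells (Homo sapiens) for antiproliferative activity (on this read-out lower numbers stand for stronger inhibition and higher numbers for weaker inhibition), compound 2 gives > 100000 nM, and this is a limit, not a number. Compound 2 therefore stands at the limit of > 100000 nM in this assay, at which 2 of the 2 values shown sit. Compound 3 `Nc1n[nH]c(N)c1/N=N/c1ccccc1CO` is next, with the change (hydroxymethyl in place of hydroxy on an aromatic carbon), hydroxymethyl in place of hydroxy on an aromatic carbon. Going by the values given here, the only measured step that bears on it is a step that the two limits leave unreadable from compound 1 to compound 2, hydroxy in place of nitro on an aromatic carbon. That step offers no size to carry over, and no gain in this assay has been seen so far in the series. No step beyond the scatter is therefore expected, and another limit is the likeliest reading. The expected change is a number no higher from compound 2 to compound 3 (the limit leaves the size open). For compound 3 the estimate is 100000 nM, with an expected range of 40000 nM to 200000 nM.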

Compound 3, half-maximal inhibitory concentration: > 100000 nM
Compound 3 gave a limit, no number; the forecaster's own chance of this, stated with the estimate: 85%; the middle value lies on the limit itself.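

In this assay compound 3 gives > 100000 nM as a limit and not as a number. Going by these compounds alone, with compound 1 and compound 2 also at limits, no step among the three compounds can be read. The compounds shown leave open whether nitro, hydroxy or hydroxymethyl on the shared core makes any difference to potency.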